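The source may report more compounds than this note shows. Statements on the series, on what has been measured and on what is new or still open speak of the compounds shown alone.

Working notes on the series, read in a functional assay on MGC-803 cells (Homo sapiens) for cytotoxicity, read by MTT assay, with a stated time of 48 h; on this read-out lower numbers stand for stronger inhibition and higher numbers for weaker inhibition.

Of the compounds shown here, two have numbers so far. Compound 1 `CC1=NN(C(=O)c2ccc(C)cc2)C(c2ccccc2O)C1` gives 26300 nM in this assay. Compound 2 `O=C(CCl)N1N=C(c2cc3ccccc3oc2=O)CC1c1ccccc1` gives 2020 nM in this assay, the lower of the two numbers; the gap to compound 1 lies beyond the scatter, so compound 2 stands as the stronger inhibitor of the pair. The two compounds differ in several places at once, so the comparison says nothing about any single change.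

The next compound to be measured is compound 3 `CC1CC(C)CN(CC(=O)N2N=C(c3cc4ccccc4oc3=O)CC2c2ccccc2)C1`. It is derived from compound 2 by one change: 3,5-dimethylpiperidin-1-yl in place of chloro on a saturated chain carbon bound to a carbonyl carbon. Among the compounds with values here, no pair of measured compounds shows a step of this kind, so there is no precedent for what a 3,5-dimethylpiperidin-1-yl in place of chloro on a saturated chain carbon bound to a carbonyl carbon does to the number.

With no guide in the data, a moderate step toward weaker inhibition is expected, a 2.0-fold higher number from compound 2 to compound 3 (0.30 log units; within the scatter), though a step in either direction of a size within the usual scatter would not surprise. Compound 3 is therefore estimated at 4000 nM, with a range of 1000 nM to 16000 nM.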

Compound 3, half-maximal inhibitory concentration: "not active" (no number reported)
Compound 3 has no reported number here; no gap can be computed for the estimate.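

In this assay, within the data shown here, compound 3 is reported as not active, with no number, so no step from compound 2 to compound 3 can be read. The compounds shown leave open how 3,5-dimethylpiperidin-1-yl in place of chloro changes the number, and what other groups at that place would give. No measured evidence bears on this result.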